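The compounds below may be only part of what the source reports. "The series", "measured", "known", "first", "only" and "open" are said of these compounds alone.

Compound 1, `O=C(Nc1ccc(Oc2cc(O)ncn2)cc1)Nc1cccc(C(F)(F)F)c1`: 3200 nM
Compound 2, `CC(=O)Nc1cc(Oc2ccc(NC(=O)Nc3cccc(C(F)(F)F)c3)cc2)ncn1`: 20 nM

Going by the values given here, in an assay on isolated protein for inhibition of serine/threonine-protein kinase TNNI3K (Homo sapiens) (a higher number here means a weaker inhibitor, a lower number a stronger inhibitor), compound 2 stands lowest of the two numbers, with compound 1 its only neighbour. Among the compounds with values here, the single measured step, a 160-fold lower number from compound 1 to compound 2 (2.20 log units; beyond the scatter), shows that the group carried on the ring oxygen moves the number strongly. Compound 3 is `O=C(Nc1ccc(Oc2ccncc2)cc1)Nc1cccc(C(F)(F)F)c1`; it differs from compound 2 by pyridin-4-yl in place of 6-acetamidopyrimidin-4-yl on an oxygen on an aromatic ring. Within the data shown here, no measured step matches this change, but the acetamido that carries compound 2 so far below compound 1 is gone, so a higher number is expected, a step of a 50-fold higher number from compound 2 to compound 3 (1.70 log units; beyond the scatter). Compound 3 is estimated at 1000 nM, within 150 nM to 6000 nM.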

Compound 3, half-maximal inhibitory concentration: 50 nM
Estimate against measurement, compound 3: 20-fold (1.30 log units) above, and the stated range ends above it.
By their numbers in this assay, from the lowest: compound 2; then compound 3; then compound 1.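

In this assay, pyridin-4-yl in place of 6-acetamidopyrimidin-4-yl gives a 2.5-fold higher number from compound 2 to compound 3 (0.40 log units; beyond the scatter) and so keeps most of the low number without the acetamido. Pyridin-4-yl in place of 6-hydroxypyrimidin-4-yl gives a 64-fold lower number from compound 1 to compound 3 (1.81 log units; beyond the scatter) and shows that the hydroxy-bearing group, not the absence of acetamido, goes with the high number of compound 1. Nothing available here explains either step.
Still open, from the compounds shown here alone, is whether an amine in place of the acetamido, or an acetamido placed on the pyridin-4-yl ring, would give a lower number than compound 2.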